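Amide swap from compound 1 to compound 3

The compounds below may be only part of what the source reports. "The series", "measured", "known", "first", "only" and "open" are said of these compounds alone.

Compound 1 `C=CC1=C(C(=O)NCc2ccc(Cl)cc2)C(c2ccc(OC)c(OC)c2)OC1` was tested in a functional assay on HeLa cells (Homo sapiens) for cytotoxicity, read by MTT assay, with a stated time of 24 h; a higher number here means a weaker inhibitor, a lower number a stronger inhibitor. In this assay compound 1 gives only a limit, > 100000 nM. Compound 2 `C=CC1=C(C(=O)NCc2ccc(Cl)cc2)C(c2ccc(OC)cc2)OC1` likewise gives only a limit in this assay, > 100000 nM. Going by the values given here, the one measured step, a step that the two limits leave unreadable from compound 1 to compound 2, is hydrogen in place of methoxy on an aromatic carbon, and its size cannot be read because both values sit at the limit of > 100000 nM in this assay, at which 2 of the 2 values shown sit. Compound 3 `C=CC1=C(C(=O)NCCC)C(c2ccc(OC)c(OC)c2)OC1` differs from compound 1 by ethyl in place of 4-chlorophenyl on a saturated chain carbon bound to an amide-type nitrogen. Among the compounds with values here, no measured step touches this part of the structure, so the read-out offers no direction. Compound 3 is therefore expected to stay at the limit as well, estimated at 150000 nM (range 40000 nM to 600000 nM). The step this estimate means is a step that the limit leaves unreadable from compound 1 to compound 3.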

Compound 3, half-maximal inhibitory concentration: > 100000 nM
Compound 3: a limit, no number; the forecaster's own chance of this, stated with the estimate: 85%; the middle value is on the limit's open side.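

No step between compound 1 and compound 3 can be read in this assay, as both give only limits: the limit of > 100000 nM in this assay, at which 3 of the 3 values shown sit.

The compounds shown leave open which change, if any, would give a number rather than a limit in this assay.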